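The compounds below may be only part of what the source reports. "The series", "measured", "known", "first", "only" and "open" are said of these compounds alone.

Compound 1 `Cn1c(=O)c(S(=O)(=O)c2ccc(C(=O)O)cc2)cc2cnc(Nc3ccc4[nH]ccc4c3)nc21`: 5000 nM
Compound 2 `Cn1c(=O)c(S(=O)(=O)Nc2ccc(F)cc2)cc2cnc(Nc3ccc4[nH]ccc4c3)nc21`: 5000 nM
Compound 3 `Cc1ccc(S(=O)(=O)c2cc3cnc(Nc4ccc5[nH]ccc5c4)nc3n(C)c2=O)cc1`: 750 nM

In a functional assay on K562 cells (Homo sapiens) for inhibition, read by trypan blue exclusion, with a stated time of 72 h (on this read-out higher numbers stand for weaker inhibition and lower numbers for stronger inhibition), compound 3 gives 750 nM, the lowest of the three numbers. Compound 4 `Cn1c(=O)c(S(=O)(=O)c2ccc(F)cc2N)cc2cnc(Nc3ccc4[nH]ccc4c3)nc21` carries 2-amino-4-fluorophenyl in place of 4-methylphenyl on a sulfonyl sulfur. Two measured steps arrive at the 4-methylphenyl group of compound 3: a 6.7-fold lower number from compound 1 to compound 3 (0.82 log units; beyond the scatter) and a 6.7-fold lower number from compound 2 to compound 3 (0.82 log units; beyond the scatter). The third step shows no change at the digits printed from compound 1 to compound 2 (within the scatter). Neither of the first two steps involves the new group, so they are only a rough guide. Losing the 4-methylphenyl group may cost a little, though probably less than those modest steps. The expected result is a 1.6-fold higher number from compound 3 to compound 4 (0.20 log units; within the scatter). For compound 4 the estimated value is 1200 nM, with an expected range of 350 nM to 4000 nM.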

Compound 4, half-maximal inhibitory concentration: 2000 nM
For compound 4 the middle estimate is 1.7-fold (0.22 log units) below the measured one; the range from low to high includes it.
By their numbers in this assay, from the lowest: compound 3; then compound 4; then compounds 1 and 2 (each within the scatter of the next).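

In this assay a ring carrying an amino group and a fluorine on the sulfonyl sulfur lands in the middle of the set, with a 2.7-fold higher number from compound 3 to compound 4 (0.43 log units; beyond the scatter) and yet also a 2.5-fold lower number from compound 2 to compound 4 (0.40 log units; beyond the scatter) and a 2.5-fold lower number from compound 1 to compound 4 (0.40 log units; beyond the scatter). So this position responds in modest steps to the group placed there, and 4-methylphenyl still gives the lowest number of the groups shown. Nothing measured here accounts for these shifts. As far as these compounds go, it remains open whether the amino group or the fluorine drives the rise from the 4-methylphenyl compound. A plain 2-aminophenyl and a 4-fluorophenyl on the same sulfur would separate the two.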